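The compounds below may be only part of what the source reports. "The series", "measured", "known", "first", "only" and "open" are said of these compounds alone.

Measured so far:
compound 1 `CC(C)(C)OC(=O)N1CCC(O[C@H]2CC[C@H](Oc3ccc(C#N)cc3)CC2)CC1`: 334 nM
compound 2 `CC(C)(C)OC(=O)N1CCC(O[C@H]2CC[C@H](Oc3cnc(S(C)(=O)=O)cn3)CC2)CC1`: 94 nM
compound 3 `CC(C)(C)OC(=O)N1CCC(O[C@H]2CC[C@H](Oc3cnc(C#N)cn3)CC2)CC1`: 144 nM

In an assay on isolated protein for agonist activity at Glucose-dependent insulinotropic receptor (Homo sapiens) (on this read-out lower numbers stand for an effect already at smaller amounts and higher numbers for an effect only at larger amounts of compound), compound 2 sits at the low end of the three numbers, though compound 3 lies within the scatter of it (a 1.5-fold higher number from compound 2 to compound 3 (0.19 log units; within the scatter)); only compound 1 is clearly set apart (a 3.6-fold lower number from compound 1 to compound 2 (0.55 log units; beyond the scatter), and a 2.3-fold lower number from compound 1 to compound 3 (0.37 log units; beyond the scatter)). Compound 4 `CC(C)OC(=O)N1CCC(O[C@H]2CC[C@H](Oc3cnc(S(C)(=O)=O)cn3)CC2)CC1` differs from compound 2 by hydrogen in place of methyl on a saturated chain carbon bound to an oxygen next to a carbonyl group and two saturated chain carbons. Among the compounds with values here, none of the measured steps touches this end of the molecule; all three vary the aryl ether on the oxygen on a saturated carbon. Nothing measured therefore bears on the change, and no step beyond the scatter is expected; the estimated move is a 1.3-fold higher number from compound 2 to compound 4 (0.11 log units; within the scatter). Compound 4 is estimated at 120 nM, within 45 nM to 320 nM.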

Compound 4, half-maximal effective concentration: 92.7 nM
The estimate for compound 4 lay 1.3-fold (0.11 log units) above the measured number; low and high end bracket the measured number.
By their numbers in this assay, from the lowest: compounds 4, 2 and 3 (each within the scatter of the next); then compound 1.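

In this assay, within the data shown here, tert-butoxycarbonyl to isopropoxycarbonyl gives a 1.0-fold lower number from compound 2 to compound 4 (0.01 log units; within the scatter), the only measured change at this end of the molecule. With 5-(methylsulfonyl)pyrazin-2-yl held fixed, this position therefore accepts the loss of one methyl with no step beyond the scatter. No supporting measurement explains this result.

On these data alone, whether the same holds with 5-cyanopyrazin-2-yl or 4-cyanophenyl remains open. Also open, as far as these compounds go, is how far the position tolerates larger departures, such as ethoxycarbonyl, cyclopropoxycarbonyl or a free amine in place of the isopropoxycarbonyl group.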